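This account rests on a few compounds, and the source may have more. Where it says the series, first, only, none or still open, it means among the compounds named here.

The series shares one core throughout; compound 1 `COC(=O)c1ccc(-c2cnc(C(O)CCc3ccc(-c4ccccc4)cc3)o2)nc1` carries a 5-(methoxycarbonyl)pyridin-2-yl group and compound 2 `O=C(O)c1cccc(-c2cnc(C(O)CCc3ccc(-c4ccccc4)cc3)o2)n1` a 6-carboxypyridin-2-yl group in its place. In an assay for inhibition of Fatty-acid amide hydrolase 1 (Rattus norvegicus) (on this read-out higher numbers stand for weaker inhibition and lower numbers for stronger inhibition), compound 1 gives 1100 nM, and compound 2 gives 1100 nM; the step of no change at the digits printed from compound 1 to compound 2 (within the scatter) is flat, so compound 2 stands level with compound 1 and the two values show no order between them.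

Compound 3 `NC(=O)c1cccc(-c2cnc(C(O)CCc3ccc(-c4ccccc4)cc3)o2)n1` is the next member. Its change from compound 2 is amino in place of hydroxy on a carbonyl carbon, that is, carboxy to carbamoyl, the 6-carboxypyridin-2-yl group becoming 6-carbamoylpyridin-2-yl. For the measured compounds named here, no measured step alters the substituent on this carbonyl carbon; the only step available, no change at the digits printed from compound 1 to compound 2 (within the scatter), concerns a different position and a different exchange, and it stayed within the scatter. With nothing pointing in either direction, the expectation in this assay is a step of about a 1.1-fold lower number from compound 2 to compound 3 (0.04 log units; within the scatter), none beyond the scatter, with the range kept wide for want of a precedent. Compound 3 is therefore estimated at 1000 nM, expected to fall between 300 nM and 3500 nM.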

Compound 3, inhibition constant: 20000 nM
Beside the measured number, compound 3's estimate is 20-fold (1.30 log units) below it; the whole stated range lies below it.
By their numbers in this assay, from the lowest: compounds 1 and 2 (each within the scatter of the next); then compound 3.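

The substituent on this carbonyl carbon matters in this assay: amino in place of hydroxy gives an 18-fold higher number from compound 2 to compound 3 (1.26 log units; beyond the scatter), although the computed comparison shows no net charge on either group and the same heavy-atom and hydrogen-bond donor counts. The exchange of 5-(methoxycarbonyl)pyridin-2-yl for 6-carbamoylpyridin-2-yl gives an 18-fold higher number from compound 1 to compound 3 (1.26 log units; beyond the scatter), whereas 6-carboxypyridin-2-yl on the same aromatic carbon gave no change at the digits printed from compound 1 to compound 2 (within the scatter), so the flat result does not extend to all three groups and the 6-carbamoylpyridin-2-yl compound alone stands apart. No measurement available here bears on what lies behind this step.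

As far as these compounds go, it remains open whether the step belongs to the amino group specifically or to other replacements of hydroxy on this carbonyl carbon, a question that methylamino, dimethylamino or methoxy on that carbon could address. The compounds shown also leave open how the 5-carboxypyridin-2-yl and 5-carbamoylpyridin-2-yl groups would compare with these three, and so whether the amino-for-hydroxy step depends on where the carbonyl group is attached.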